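The compounds below may be only part of what the source reports. "The series", "measured", "known", "first", "only" and "open" are said of these compounds alone.

Measured compounds:
Compound 1, `CCCSc1nc2nc(C)cc(N3CC[C@@H](C)[C@@H](N(C)c4ncnc5[nH]ccc45)C3)n2n1`: 15500 nM
Compound 2, `Cc1cc(N2CC[C@@H](C)[C@@H](N(C)c3ncnc4[nH]ccc34)C2)n2nc(SCC3CCCCC3)nc2n1`: 9170 nM
Compound 3, `Cc1cc(N2CC[C@@H](C)[C@@H](N(C)c3ncnc4[nH]ccc34)C2)n2nc(SCc3ccc([N+](=O)[O-])cc3)nc2n1`: 27000 nM

These three share one core and differ only in the group carried on the sulfur. In a functional assay on MGC-803 cells (Homo sapiens) for inhibition, read by MTT assay, with a stated time of 72 h (a lower number here means a stronger inhibitor, a higher number a weaker inhibitor), compound 3 gives the highest of the three numbers, though the step of a 1.7-fold higher number from compound 1 to compound 3 (0.24 log units; within the scatter) is within the scatter, while the step of a 2.9-fold higher number from compound 2 to compound 3 (0.47 log units; beyond the scatter) is modest and beyond it. Compound 4, `Cc1ccc(CSc2nc3nc(C)cc(N4CC[C@@H](C)[C@@H](N(C)c5ncnc6[nH]ccc56)C4)n3n2)cc1`, has not yet been measured in this assay. It differs from compound 3 in one place: methyl in place of nitro on an aromatic carbon.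

Going by the values given here, no measured step swaps a nitro for a methyl, so the expectation rests only on the neighbours. The step of a 2.9-fold higher number from compound 2 to compound 3 (0.47 log units; beyond the scatter) shows that exchanging the group on the sulfur can move the number modestly, and the step of a 1.7-fold lower number from compound 1 to compound 2 (0.23 log units; within the scatter) shows that it can also leave it unchanged. A small shift in either direction, or none beyond the scatter, is therefore expected for compound 4, with a 1.7-fold lower number from compound 3 to compound 4 (0.23 log units; within the scatter) as the expected step. Compound 4 is estimated at 16000 nM, within a range from 6000 nM to 40000 nM.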

Compound 4, half-maximal inhibitory concentration: 5860 nM
For compound 4 the middle estimate is 2.7-fold (0.44 log units) above the measured one; the measured number lies below the stated range.
By their numbers in this assay, from the lowest: compounds 4, 2, 1 and 3 (each within the scatter of the next, the first and the last beyond it).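

In this assay the group on the aromatic ring, para to a large group, proves to matter: methyl in place of nitro gives a 4.6-fold lower number from compound 3 to compound 4 (0.66 log units; beyond the scatter), the first measured change made on the ring itself. The ring group also alters how the whole substituent on the sulfur compares with the others: a 2.6-fold lower number from compound 1 to compound 4 (0.42 log units; beyond the scatter) is beyond the scatter, whereas the 4-nitrophenyl step from the same starting compound was not, and a 1.6-fold lower number from compound 2 to compound 4 (0.19 log units; within the scatter) leaves 4-methylphenyl level with cyclohexyl. No measurement shown here accounts for these differences.

With only nitro and methyl on the ring, the compounds shown leave open where a chlorine, a methoxy group, an amine or plain hydrogen at this place would fall. They also leave open whether methyl would have the same effect on another carbon of the ring.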